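Compound 3 to compound 4: piperazin-1-yl on the shared core

This account rests on a few compounds, and the source may have more. Where it says the series, first, only, none or still open, it means among the compounds named here.

- compound 1 `N#Cc1c(O)nc(SCc2nc3ccccc3[nH]2)nc1-c1ccccc1`: 7.81 nM
- compound 2 `N#Cc1c(Nc2ccccc2)nc(SCc2nc3ccccc3[nH]2)nc1-c1ccccc1`: 6.41 nM
- compound 3 `N#Cc1c(Nc2nccs2)nc(SCc2nc3ccccc3[nH]2)nc1-c1ccccc1`: 5.1 nM

In a functional assay on GOTO cells (Homo sapiens) for cytotoxicity, read by MTT assay, with a stated time of 3 days (a lower number here means a stronger inhibitor, a higher number a weaker inhibitor), compound 3, at 5.1 nM, lies within the scatter of both compound 1 and compound 2, so the three cannot be ordered. Compound 4 `N#Cc1c(-c2ccccc2)nc(SCc2nc3ccccc3[nH]2)nc1N1CCNCC1` has piperazin-1-yl in place of (1,3-thiazol-2-yl)amino on an aromatic carbon.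

The three measured changes at this same aromatic carbon all stay within the scatter: a 1.2-fold lower number from compound 1 to compound 2 (0.09 log units; within the scatter), a 1.5-fold lower number from compound 1 to compound 3 (0.19 log units; within the scatter) and a 1.3-fold lower number from compound 2 to compound 3 (0.10 log units; within the scatter). None of them brings in a non-aromatic ring, so this support is indirect and the range is kept wide. The step expected in this assay is a 1.2-fold higher number from compound 3 to compound 4 (0.07 log units; within the scatter), with nothing expected beyond the scatter. For compound 4 the estimate is 6 nM, with an expected range of 2.5 nM to 15 nM.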

Compound 4, half-maximal inhibitory concentration: 3.7 nM
The estimate for compound 4 lay 1.6-fold (0.21 log units) above the measured number; low and high end bracket the measured number.
By their numbers in this assay, from the lowest: compounds 4, 3, 2 and 1 (each within the scatter of the next, the first and the last beyond it).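

In this assay, a non-aromatic ring on this aromatic carbon stays in the range of the aromatic amino groups: a 1.4-fold lower number from compound 3 to compound 4 (0.14 log units; within the scatter) and a 1.7-fold lower number from compound 2 to compound 4 (0.24 log units; within the scatter) are both read as no real difference. Within the data shown here, only the comparison with the hydroxy compound passes the scatter, and only modestly, with a 2.1-fold lower number from compound 1 to compound 4 (0.32 log units; beyond the scatter), the first step at this position to do so. Nothing available explains this step.

Going by these compounds, whether morpholin-4-yl or an open-chain amine such as dimethylamino would read the same on this carbon remains open. Also open, on these data alone, is the effect of a methyl group on the free piperazine nitrogen.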